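Anilide series: bromo exchanged for trifluoromethyl

The compounds below may be only part of what the source reports. "The series", "measured", "known", "first", "only" and "open" are said of these compounds alone.

Measured so far:
compound 1 `O=C(Nc1ccccc1[N+](=O)[O-])C(Cl)Cl`: 198000 nM
compound 2 `O=C(Nc1cccc(Br)c1)C(Cl)Cl`: 7800 nM

Both numbers come from a functional assay on A549 cells (Homo sapiens) for antiproliferative activity, read by MTT assay, with a stated time of 72 h; a lower number here means a stronger inhibitor, a higher number a weaker inhibitor. Compound 2 stands lowest of the two; the nearest, compound 1, sits higher by a gap beyond the scatter, so compound 2 is the stronger of the pair in this assay. Compound 3 `O=C(Nc1cccc(C(F)(F)F)c1)C(Cl)Cl` is not yet measured. It differs from compound 2 by trifluoromethyl in place of bromo on an aromatic carbon. Within the data shown here, no measured pair shows this kind of change, so no step beyond the scatter is expected. The expected step is a 1.0-fold higher number from compound 2 to compound 3 (0.01 log units; within the scatter). Compound 3 is estimated at 8000 nM, range 3000 nM to 25000 nM.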

Compound 3, half-maximal inhibitory concentration: 12200 nM
Estimate against measurement, compound 3: 1.5-fold (0.18 log units) below, within the range that was stated.
By their numbers in this assay, from the lowest: compounds 2 and 3 (each within the scatter of the next); then compound 1.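

Trifluoromethyl in place of bromo on this aromatic carbon gives a 1.6-fold higher number from compound 2 to compound 3 (0.19 log units; within the scatter) and so does not separate the two groups, although four heavy atoms replace one. Among these compounds, this is the first comparison between compounds that differ in one place, which the earlier pair could not provide. No measurement at hand bears on why the two groups read alike.

Still open, as far as these compounds go, is how an amine or a carboxylic acid would read in this place. Also open, from the compounds shown here alone, is whether the same exchange would read alike elsewhere on the ring.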